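From 3-methoxyphenyl to 4-fluorophenyl on a carbonyl carbon

A few compounds are considered here, and "the series" means these few. Any claim that something is new, unique, unknown or untested is made for them only; others in the source may bear on it.

Of the compounds shown here, three sharing one core have been tested in an ADME assay on Karpas-1106P cells (Homo sapiens) for cytotoxicity; a higher number here means that more compound is needed for the effect, a lower number that less compound is needed. Compound 1 `Cc1ccc(S(=O)(=O)N[C@@H](CC(=O)NC(C)(C)C)C(=O)NCCNC(=O)c2cccc(O)c2)cc1` carries 3-hydroxyphenyl on a carbonyl carbon, compound 2 `Cc1ccc(S(=O)(=O)N[C@@H](CC(=O)NC(C)(C)C)C(=O)NCCNC(=O)Nc2ccccc2)cc1` carries anilino there, and compound 3 `COc1cccc(C(=O)NCCNC(=O)[C@H](CC(=O)NC(C)(C)C)NS(=O)(=O)c2ccc(C)cc2)c1` carries 3-methoxyphenyl.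

Compound 1 gives > 11100 nM, which is a limit of the assay and not a number. Compound 2 gives > 11100 nM, again a limit. Compound 3 gives > 11100 nM, also a limit. Within the data shown here, compound 3 therefore has no exact value and stands level with the other two on the only information available: the limit of > 11100 nM in this assay, at which 3 of the 3 values shown sit.

The next compound is compound 4 `Cc1ccc(S(=O)(=O)N[C@@H](CC(=O)NC(C)(C)C)C(=O)NCCNC(=O)c2ccc(F)cc2)cc1`, with this change: 4-fluorophenyl in place of 3-methoxyphenyl on a carbonyl carbon. The measured steps that bear on it are a step that the two limits leave unreadable from compound 1 to compound 2, a step that the two limits leave unreadable from compound 1 to compound 3 and a step that the two limits leave unreadable from compound 2 to compound 3. None of them has a size that can be read, so they offer no direction for the new change. Among the measured compounds shown here, no compound so far has given an exact number in this assay, so no clear rise or fall is expected. The expected step, a step that the limit leaves unreadable from compound 3 to compound 4, is only a rough estimate. Compound 4 is expected to lie near 15000 nM, within an estimated range of 6000 nM to 40000 nM, and will most likely be reported as a limit too.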

Compound 4, half-maximal effective concentration: > 11100 nM
Compound 4 gave a limit, no number; the forecaster's own chance of this, stated with the estimate: 85%; the middle value lies beyond the limit too.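

In this assay compound 4 gives > 11100 nM, which is a limit of the assay and not a number. The steps from compound 4 to compound 1, compound 2 and compound 3 cannot be read, because all four compounds share the same limit: the limit of > 11100 nM in this assay, at which 4 of the 4 values shown sit.

The compounds shown leave open what exact value any of them has, and whether any change on the carbonyl carbon shifts it.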